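This account rests on a few compounds, and the source may have more. Where it says the series, first, only, none or still open, it means among the compounds named here.

Measured compounds in a functional assay on HEK293 cells for agonist activity at Free fatty acid receptor 1 (Homo sapiens), read by fluorescence and calcium flux, with a stated time of 10 min; on this read-out higher numbers stand for an effect only at larger amounts of compound and lower numbers for an effect already at smaller amounts:
compound 1 `COc1ccc2c(c1)OC(COc1ccc(CCC(=O)O)c(F)c1)CC2` gives 2110 nM in this assay
compound 2 `COCCOc1ccc2c(c1)OC(COc1ccc(CCC(=O)O)c(F)c1)CC2` gives 2370 nM in this assay
compound 3 `COc1ccc2c(c1)OC(COc1ccc(CCC(=O)O)c(F)c1)CO2` gives 1470 nM in this assay

Compound 3 shows the lowest of the three numbers, yet its gaps to compound 1 and to compound 2 are both within the usual scatter, so no order among the three can be claimed. For the measured compounds named here, the one step between measured compounds that differ in a single place, a 1.1-fold higher number from compound 1 to compound 2 (0.05 log units; within the scatter), concerns the saturated chain carbon bound to the aromatic oxygen and stays within the scatter.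

Compound 4 `O=C(O)CCc1ccc(OCC2COc3ccc(Cl)cc3O2)cc1F` differs from compound 3 by chloro in place of methoxy on an aromatic carbon. Going by the values given here, no measured pair exchanges a substituent on that aromatic carbon of the fused system, so the change has no direct anchor; the only step on hand, a 1.1-fold higher number from compound 1 to compound 2 (0.05 log units; within the scatter), sits elsewhere and is flat. A step of no more than the scatter is therefore expected in this assay, with no direction favoured. Compound 4 is estimated at 1300 nM, with a range from 400 nM to 4000 nM in this assay. This estimate corresponds to an expected step of a 1.1-fold lower number from compound 3 to compound 4 (0.05 log units; within the scatter) in this assay.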

Compound 4, half-maximal effective concentration: 830 nM
Compound 4: the middle estimate sits 1.6-fold (0.19 log units) above what was measured; the measured number falls inside the stated range.
By their numbers in this assay, from the lowest: compounds 4, 3, 1 and 2 (each within the scatter of the next, the first and the last beyond it).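

In this assay, for the compounds shown here, the exchange of methoxy for chloro on this aromatic carbon gives a 1.8-fold lower number from compound 3 to compound 4 (0.25 log units; within the scatter) and is the first measured step at this position of the shared core. In this one pair, methoxy, which carries the hydrogen-bond acceptor, can give way to chloro, which carries none, without a step beyond the scatter. No measurement shown here bears on the reason for this step.

Going by these compounds, whether other groups on this aromatic carbon, such as fluoro, trifluoromethyl, nitrile or an amine, stay within the scatter of compound 3 remains open. Also open, on these data alone, is whether chloro in place of methoxy on the core of compound 1 gives a step of similar size, so the reach of this single pair across the series is unknown.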